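A few compounds are considered here, and "the series" means these few. Any claim that something is new, unique, unknown or untested is made for them only; others in the source may bear on it.

Among the measured compounds shown here, compound 2 `COc1ccc(/C=N/NC(=O)c2ccc(-c3nc4ccccc4s3)cc2)cc1` gives 18300 nM in an assay on isolated protein for inhibition of Maltase-glucoamylase (Homo sapiens), with a stated time of 15 min (on this read-out higher numbers stand for weaker inhibition and lower numbers for stronger inhibition), one of two numbers measured so far; the other belongs to compound 1 `O=C(N/N=C/c1ccc(O)cc1)c1ccc(-c2nc3ccccc3s2)cc1`, which gives 11300 nM, and the step of a 1.6-fold higher number from compound 1 to compound 2 (0.21 log units; within the scatter) lies within the scatter. Compound 3 `O=C(N/N=C/c1cc(O)ccc1O)c1ccc(-c2nc3ccccc3s2)cc1` differs from compound 2 by 2,5-dihydroxyphenyl in place of 4-methoxyphenyl on a carbon with a double bond to nitrogen. For the measured compounds named here, only that step from compound 1 to compound 2 touches this change, and it was small, so in this assay the expected step is a 1.8-fold lower number from compound 2 to compound 3 (0.26 log units; within the scatter), no more than the scatter, if anything toward a lower number. Compound 3 is therefore estimated at 10000 nM, between 3000 nM and 35000 nM.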

Compound 3, half-maximal inhibitory concentration: 11900 nM
Compound 3: the middle estimate sits 1.2-fold (0.08 log units) below what was measured; low and high end bracket the measured number.
By their numbers in this assay, from the lowest: compounds 1, 3 and 2 (each within the scatter of the next).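

In this assay, putting 2,5-dihydroxyphenyl in place of 4-methoxyphenyl gives a 1.5-fold lower number from compound 2 to compound 3 (0.19 log units; within the scatter), and putting it in place of 4-hydroxyphenyl gives a 1.1-fold higher number from compound 1 to compound 3 (0.02 log units; within the scatter). Among the compounds shown here, the position on a carbon with a double bond to nitrogen has thus taken three different substituted phenyl groups, including one with 2 hydrogen-bond donors, and no step has left the scatter. Nothing available accounts for this flat result. On these data alone, it remains open whether an amine or a carboxylic acid on this phenyl ring would move the number beyond the scatter, and whether a change in the shared core would do so.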